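A Hydroxy-Methyl Swap on an Adenosine Benzylamine

A few compounds are considered here, and "the series" means these few. Any claim that something is new, unique, unknown or untested is made for them only; others in the source may bear on it.

Compound 3 `COc1cccc(CNc2ncnc3c2ncn3[C@@H]2O[C@H](CO)[C@@H](O)[C@H]2O)c1OC` has no result of its own in a functional assay on G-361 cells (Homo sapiens) for antiproliferative activity, with a stated time of 72 h (on this read-out lower numbers stand for stronger inhibition and higher numbers for weaker inhibition), where its entry reads "not determined" (no result reported). Compound 1 `OC[C@H]1O[C@@H](n2cnc3c(NCc4ccccc4F)ncnc32)[C@H](O)[C@@H]1O` likewise has no reported value in this assay, where its entry reads "not determined" (no result reported). Among the measured compounds shown here, compound 2 `OC[C@H]1O[C@@H](n2cnc3c(NCc4cccc(F)c4)ncnc32)[C@H](O)[C@@H]1O` gives only a limit in this assay, > 166000 nM, so that a limit rather than a number is all that stands behind the series so far (the limit of > 166000 nM in this assay, at which 1 of the 3 values shown sits). Compound 4 `Cc1cccc(CNc2ncnc3c2ncn3[C@@H]2O[C@H](CO)[C@@H](O)[C@H]2O)c1O` carries 2-hydroxy-3-methylphenyl in place of 2,3-dimethoxyphenyl on a saturated chain carbon bound to a nitrogen on an aromatic ring. The change leaves the shared core untouched and alters only the aryl group, so the step from compound 3 is expected to be small, within the scatter or at most modest in either direction. Since compound 2 reaches only the limit > 166000 nM in this assay, weak inhibition is expected for the set. Compound 4 is therefore estimated at 100000 nM in this assay, with a likely span from 20000 nM to 300000 nM.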

Compound 4, half-maximal inhibitory concentration: > 166000 nM
Compound 4 gave a limit, no number; the forecaster's own chance of this, stated with the estimate: 50%; middle value at least 1.6-fold (0.22 log units) away from the limit.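

No step can be read from compound 4, since compound 2 and compound 4 both stand only as limits and compound 3 has no result. The compounds shown leave open whether changing the aryl group shifts the result in this assay: the limit of > 166000 nM in this assay, at which 2 of the 4 values shown sit.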